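Ester chain extension, ethyl to isopropyl, on two cores

A few compounds are considered here, and "the series" means these few. Any claim that something is new, unique, unknown or untested is made for them only; others in the source may bear on it.

Measured compounds:
compound 1 `CCOC(=O)C1=C(C)NC(=S)NC1c1ccoc1`, 18%
compound 2 `CC1=C(C(=O)OC(C)C)C(c2ccoc2)NC(=S)N1`, 18%
compound 3 `CCOC(=O)C1=C(C)N(C)C(=O)NC1c1ccoc1`, 17%

In an assay on CHO cells for displacement of a labelled ligand from adenosine receptor A1 (Homo sapiens), with a stated time of 60 min, tested at 10 uM (a lower number here means less inhibition, a higher number more inhibition at the concentration tested (going by the name of the read-out)), compound 1 gives 18% and compound 2 gives 18%. The change between them is methyl in place of hydrogen on a saturated chain carbon bound to an oxygen next to a carbonyl group and a saturated chain carbon, and the step it made is no change at the digits printed from compound 1 to compound 2 (within the scatter). Compound 3 gives 17% in this assay; the difference between the core of compound 3 and the core of compound 1 is not broken down here. Compound 4 `CC1=C(C(=O)OC(C)C)C(c2ccoc2)NC(=O)N1C` has not yet been measured. It differs from compound 3 by methyl in place of hydrogen on a saturated chain carbon bound to an oxygen next to a carbonyl group and a saturated chain carbon, the same change as from compound 1 to compound 2, at a place described in the same words. The step of no change at the digits printed from compound 1 to compound 2 (within the scatter) shows that change leaving the read-out where it was on the core of compound 1. Due to no change at the digits printed from compound 1 to compound 2 (within the scatter) the step expected on the core of compound 3 is no change at the digits printed from compound 3 to compound 4 (within the scatter). Compound 4 is thus estimated at 17% in this assay, with a range from 7% to 27%. This rests on one measured pair only.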

Compound 4, a percentage reported as inhibition, at one concentration (the size of the read-out at that concentration, not a potency): 23%
Beside the measured number, compound 4's estimate is 6 percentage points below it; the measured number falls inside the stated range.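

In this assay, the change from ethyl to isopropyl gives a number 6 percentage points higher from compound 3 to compound 4 (within the scatter), and set beside the earlier step on the other core it reads as follows: the same change on two cores in this assay, no change at the digits printed (within the scatter) from compound 1 to compound 2 and a number 6 percentage points higher (within the scatter) from compound 3 to compound 4, 6 percentage points apart, within the scatter of two such steps

Within this assay, the change therefore carries from the core of compound 1 to the core of compound 3 with no difference that can be told from the scatter. This does not show that the change is without effect in general: it rests on two matched pairs, each read at a single concentration, which gives the size of the read-out and not a potency, and it says nothing about other receptors or other cores.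

The difference between the two cores themselves remains unresolved, as no listed pair isolates it. Also open, going by these compounds, is whether a longer chain such as butoxycarbonyl, or a carboxylic acid in place of the ethoxycarbonyl group, would shift the read-out beyond the scatter on either core.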